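A Chloro Step on a Benzoyl Group

A few compounds are considered here, and "the series" means these few. Any claim that something is new, unique, unknown or untested is made for them only; others in the source may bear on it.

Values measured in an ADME assay on SH-SY5Y cells (Homo sapiens) for cytotoxicity, read by MTT assay, with a stated time of 72 h; a higher number here means a weaker inhibitor, a lower number a stronger inhibitor:
- Compound 1 `O=C(CN1CCN(C(=O)c2ccc(Cl)cc2)CC1)N1CCN(CCCc2c[nH]c3ccccc23)CC1`: 139000 nM
- Compound 2 `O=C(CN1CCN(C(=O)c2ccc(Cl)cc2)CC1)N1CCN(CCCc2c[nH]c3ccc(F)cc23)CC1`: 125000 nM
- Compound 3 `COc1ccc2[nH]cc(CCCN3CCN(C(=O)CN4CCN(C(=O)c5ccccc5)CC4)CC3)c2c1`: > 200000 nM

Compound 3 has no number on this scale, and its > 200000 nM is a limit of this assay.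

Compound 4 `COc1ccc2[nH]cc(CCCN3CCN(C(=O)CN4CCN(C(=O)c5ccc(Cl)cc5)CC4)CC3)c2c1` differs from compound 3 by chloro in place of hydrogen on an aromatic carbon, which turns benzoyl to (4-chlorophenyl)carbonyl. For the measured compounds named here, no measured step makes this same change. The nearest is a 1.1-fold lower number from compound 1 to compound 2 (0.05 log units; within the scatter), a fluoro in place of hydrogen on an aromatic carbon, and it gives no reason to expect a large effect from such a small swap. The better guide is that the (4-chlorophenyl)carbonyl group also occurs in compound 1, at 139000 nM, and in compound 2, at 125000 nM. Neither of them carries the methoxy group shared by compound 3 and compound 4, so the comparison is imperfect. A modest move toward a lower number is therefore expected, with a real chance that compound 4 also ends at the limit. The expected change is an at least 1.4-fold lower number from compound 3 to compound 4 (0.17 log units; that floor lies within the scatter). For compound 4 the estimate is 135000 nM, with an expected range from 75000 nM to 200000 nM.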

Compound 4, half-maximal inhibitory concentration: 159000 nM
The estimate for compound 4 lay 1.2-fold (0.07 log units) below the measured number; the range from low to high includes it.
By their numbers in this assay, from the lowest: compounds 2, 1 and 4 (each within the scatter of the next). At a limit, above all of these: compound 3.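

With the (4-chlorophenyl)carbonyl group held fixed, the group on the other side of the molecule makes no measurable difference: methoxy in place of fluoro gives a 1.3-fold higher number from compound 2 to compound 4 (0.10 log units; within the scatter), and methoxy in place of hydrogen gives a 1.1-fold higher number from compound 1 to compound 4 (0.06 log units; within the scatter). Chloro in place of hydrogen, on an aromatic carbon para to a large group, brings the methoxy compounds onto the measurable scale for the first time, with an at least 1.2-fold lower number from compound 3 to compound 4 (0.09 log units; that floor lies within the scatter), so only a floor on this step can be read. In this assay, compound 3 still has a limit and not a number: the limit of > 200000 nM in this assay, at which 1 of the 4 values shown sits.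

On these data alone, whether an amine or a nitrile in place of the chloro would separate from compound 4 beyond the scatter stays open. Also open, as far as these compounds go, is the true value of compound 3, and with it the full size of the chloro step.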